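This account rests on a few compounds, and the source may have more. Where it says the series, first, only, none or still open, it means among the compounds named here.

Measured so far:
compound 1 `O=C(/C=C/c1ccc2cc(C(=O)c3ccc(F)cc3)ccc2n1)NO` gives 1260 nM
compound 2 `Cc1ccc(C(=O)c2ccc3nc(/C=C/C(=O)NO)ccc3c2)cc1` gives 2580 nM

Going by the values given here, in a functional assay on A549 cells (Homo sapiens) for antiproliferative activity, read by sulforhodamine B assay, with a stated time of 48 h (a lower number here means a stronger inhibitor of growth, a higher number a weaker inhibitor of growth), compound 1 at 1260 nM holds the lower of the two numbers, with compound 2 as its only neighbour at 2580 nM on the higher side. Compound 3 `COc1ccc(C(=O)c2ccc3nc(/C=C/C(=O)NO)ccc3c2)cc1` keeps the core of compound 1 and changes in one place. methoxy in place of fluoro on an aromatic carbon is that change, methoxy in place of fluoro on an aromatic carbon, para to a large group. Among the compounds with values here, one measured step bears on it, the swap of methyl in place of fluoro on an aromatic carbon, which shows a 2.0-fold higher number from compound 1 to compound 2 (0.31 log units; beyond the scatter) and counts as modest. Within the data shown here, no methoxy compound has been measured yet, so a modest step of similar size toward a higher number is expected in this assay on this single precedent. The expected step is a 1.6-fold higher number from compound 1 to compound 3 (0.20 log units; within the scatter) in this estimate. For compound 3 the estimated value is 2000 nM with an expected range from 900 nM to 4500 nM.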

Compound 3, concentration for 50% growth inhibition: 1890 nM
For compound 3 the middle estimate is 1.1-fold (0.02 log units) above the measured one; the range from low to high includes it.
By their numbers in this assay, from the lowest: compounds 1, 3 and 2 (each within the scatter of the next, the first and the last beyond it).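

In this assay, the change from 4-fluorophenyl to 4-methoxyphenyl gives a 1.5-fold higher number from compound 1 to compound 3 (0.18 log units; within the scatter) and so, unlike the methyl swap, does not separate the new compound from the fluoro compound. Methoxy in place of methyl gives a 1.4-fold lower number from compound 2 to compound 3 (0.14 log units; within the scatter) and leaves compound 3 within the scatter of both neighbours, even though those two neighbours lie beyond the scatter of each other with a 2.0-fold higher number from compound 1 to compound 2 (0.31 log units; beyond the scatter) in this assay. This place, para to a large group, therefore accepts a methoxy group with its added hydrogen-bond acceptor without any step larger than the modest one already seen.

The compounds shown leave open whether an amine, a carboxylic acid or a longer alkoxy chain here would stay in this narrow range. They also leave open how a hydrogen at this place would compare. Nothing at hand explains these small steps.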